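Toward compound 4: an amino-linked methoxyphenyl on the core

The source may hold more compounds than are shown below. What is called first, only, known or untested is meant among the compounds shown, and "the series" means these compounds.

Measured so far in an assay on CHO cells for displacement of a labelled ligand from prostaglandin E2 receptor EP1 subtype (Homo sapiens); on this read-out lower numbers stand for stronger inhibition and higher numbers for weaker inhibition:
compound 1 `COc1ccc(Cc2nnc(CN(c3cccc(Cl)c3C)S(=O)(=O)c3ccc(C)cc3)o2)cc1` gives 6.31 nM;
compound 2 `Cc1ccc(S(=O)(=O)N(Cc2nnc(Cc3cccc(F)c3)o2)c2cccc(Cl)c2C)cc1` gives 316 nM;
compound 3 `Cc1ccc(S(=O)(=O)N(Cc2nnc(Cc3cccc(Cl)c3)o2)c2cccc(Cl)c2C)cc1` gives 158 nM.

Compound 3 holds the second highest of the three numbers. It sits within the scatter of compound 2, as the step of a 2.0-fold lower number from compound 2 to compound 3 (0.30 log units; within the scatter) shows, while the step of a 25-fold higher number from compound 1 to compound 3 (1.40 log units; beyond the scatter) sets it far from compound 1.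

Compound 4 `COc1ccc(Nc2nnc(CN(c3cccc(Cl)c3C)S(=O)(=O)c3ccc(C)cc3)o2)cc1` differs from compound 3 by (4-methoxyphenyl)amino in place of 3-chlorobenzyl on an aromatic carbon. Among the measured compounds shown here, the steps of a 50-fold higher number from compound 1 to compound 2 (1.70 log units; beyond the scatter) and a 25-fold higher number from compound 1 to compound 3 (1.40 log units; beyond the scatter) bear on this change in the sense that a 4-methoxyphenyl group at that end went with much lower numbers; the amino linker of compound 4 has no measured counterpart. A large step toward a lower number in this assay is therefore expected, a 7.9-fold lower number from compound 3 to compound 4 (0.90 log units; beyond the scatter), giving for compound 4 an estimate of 20 nM, between 4 nM and 100 nM.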

Compound 4, half-maximal inhibitory concentration: 31.6 nM
Compound 4: the middle estimate sits 1.6-fold (0.20 log units) below what was measured; the measured number falls inside the stated range.
By their numbers in this assay, from the lowest: compound 1; then compound 4; then compounds 3 and 2 (each within the scatter of the next).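

In this assay the amino link proves compatible with a 4-methoxyphenyl end, but with that end held constant, replacing the 4-methoxybenzyl group gives a 5.0-fold higher number from compound 1 to compound 4 (0.70 log units; beyond the scatter) and so costs part of the advantage of compound 1. Compound 4 still keeps a clear margin over the halogenated benzyl compounds, as shown by a 5.0-fold lower number from compound 3 to compound 4 (0.70 log units; beyond the scatter) and by a 10-fold lower number from compound 2 to compound 4 (1.00 log units; beyond the scatter) in the same read-out. No measurement given here accounts for these differences.

Going by these compounds, it remains open how an ether oxygen or a longer chain would compare as the link at this position. The separate contribution of the methoxy group on the amino-linked ring is also open, since a 3-chlorophenyl or unsubstituted phenyl group on that link is not among the compounds shown.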